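The source may report more compounds than this note shows. Statements on the series, on what has been measured and on what is new or still open speak of the compounds shown alone.

Measured so far:

compound 1, `Nc1n[nH]c2cc(-c3ccc(=O)n(Cc4ccccc4)c3)ccc12` — 79 nM
compound 2, `O=c1ccc(-c2ccc3cn[nH]c3c2)cn1Cc1ccccc1C(F)(F)F` — 133 nM

Both numbers come from an assay for inhibition of MAP kinase-interacting serine/threonine-protein kinase 1 (Homo sapiens), read by luminescence and ADP-Glo, with a stated time of 2 h; a higher number here means a weaker inhibitor, a lower number a stronger inhibitor. Compound 1 has the lowest of the two numbers, and compound 2 sits closest to it; the gap between them lies within the scatter of this assay, so the two values cannot be ordered. Compound 2 also differs from compound 1 in more than one place, so nothing is read from that pair about any single change.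

The unmeasured compound 3, `Nc1n[nH]c2cc(-c3ccc(=O)n(Cc4cccc(Cl)c4)c3)ccc12`, differs from compound 1 in one place: chloro in place of hydrogen on an aromatic carbon. Chloro in place of hydrogen on an aromatic carbon, the benzyl becoming 3-chlorobenzyl, is a small change away from the shared core. Among the measured compounds shown here, with no comparable step among the measured compounds, the step of a 1.1-fold lower number from compound 1 to compound 3 (0.05 log units; within the scatter) is expected to be small, within or near the scatter, in no firm direction. Compound 3 is estimated at 70 nM, in the range 30 nM to 160 nM.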

Compound 3, half-maximal inhibitory concentration: 11 nM
Compound 3: the middle estimate sits 6.4-fold (0.80 log units) above what was measured; measured number outside the range, below it.
By their numbers in this assay, from the lowest: compound 3; then compounds 1 and 2 (each within the scatter of the next).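

In this assay, a single chloro on the benzyl group, turning it into 3-chlorobenzyl, gives a 7.2-fold lower number from compound 1 to compound 3 (0.86 log units; beyond the scatter). This shows that the benzyl ring is a place where adding just one heavy atom can clearly shift the number, something compound 1 and compound 2 could not show, as they differ in more than one place. Nothing available here accounts for the size of this step.

On these data alone, it remains open whether this gain is specific to chloro or would also come with another group at the same place, such as fluoro, methyl or methoxy. As far as these compounds go, it is also open whether chloro elsewhere on the same ring would give a similar step.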